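Growing the aromatic substituent on a nucleoside-like cytotoxic scaffold

The compounds below may be only part of what the source reports. "The series", "measured", "known", "first", "only" and "open" are said of these compounds alone.

Measured so far:
Compound 1, `CCCCCc1cc(-c2cn([C@H]3C[C@H](OC(C)=O)[C@@H](COC(C)=O)O3)c(=O)[nH]c2=O)on1`: 88.9%
Compound 2, `CC(=O)OC[C@H]1O[C@@H](n2cc(-c3cc(-c4ccccc4)no3)c(=O)[nH]c2=O)C[C@@H]1OC(C)=O`: 91.4%
Compound 3, `CC(=O)OC[C@H]1O[C@@H](n2cc(-c3cc(C)no3)c(=O)[nH]c2=O)C[C@@H]1OC(C)=O`: 101%

All three values come from a functional assay on NCI-H23 cells (Homo sapiens) for cytotoxicity, read by sulforhodamine B assay, tested at 10 uM; a lower number here means less inhibition, a higher number more inhibition at the concentration tested (going by the name of the read-out). Compound 3 carries the highest of the three numbers, but only compound 1 sits beyond the scatter below it, a number 12.1 percentage points higher from compound 1 to compound 3 (beyond the scatter); compound 2 lies within the scatter of compound 3, a number 9.6 percentage points higher from compound 2 to compound 3 (within the scatter), so no order between compounds 2 and 3 can be claimed. Swapping pentyl for phenyl also changed little, a number 2.5 percentage points higher from compound 1 to compound 2 (within the scatter).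

Compound 4, `CC(=O)OC[C@H]1O[C@@H](n2cc(-c3cc(-c4ccc(C(C)C)cc4)no3)c(=O)[nH]c2=O)C[C@@H]1OC(C)=O`, is not yet measured. It differs from compound 3 by 4-isopropylphenyl in place of methyl on an aromatic carbon. Among the compounds with values here, the step that bears most directly on it is the one between compound 2 and compound 3, which covers the reverse exchange, a phenyl against a methyl at this same place, and amounted to a shift inside the scatter. Within the data shown here, compound 4 carries a larger group than compound 2 does, and no measured step covers such a group, so the expectation is a small decrease at most, perhaps none beyond the scatter.

Compound 4 is therefore expected to give about 92% in this assay, between 78% and 102%, an estimated step of a number 9 percentage points lower from compound 3 to compound 4 (within the scatter).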

Compound 4, a percentage reported as inhibition, at one concentration (the size of the read-out at that concentration, not a potency): 108%
Compound 4: the middle estimate sits 16 percentage points below what was measured; the whole stated range lies below it.
By their numbers in this assay, from the lowest: compounds 1, 2, 3 and 4 (each within the scatter of the next, the first and the last beyond it).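

In this assay, the place next to the ring nitrogen accepts a much larger group than methyl without a loss of inhibition, with 4-isopropylphenyl in place of methyl giving a number 7 percentage points higher from compound 3 to compound 4 (within the scatter). Within the data shown here, the new compound also gives the first evidence that a substituent on the added phenyl ring can matter: adding isopropyl to the phenyl group gives a number 16.6 percentage points higher from compound 2 to compound 4 (beyond the scatter), and replacing pentyl with 4-isopropylphenyl gives a number 19.1 percentage points higher from compound 1 to compound 4 (beyond the scatter), whereas phenyl in place of pentyl gave only a number 2.5 percentage points higher from compound 1 to compound 2 (within the scatter). Nothing available here accounts for these differences.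

The compounds shown leave open whether an amine or a carboxylic acid at the same spot on the phenyl ring would keep this level of inhibition, and whether a longer chain in place of isopropyl would do the same. Every value comes from a single tested concentration, and the numbers all lie close together at the high end. How the compounds differ in potency also remains unanswered, as does what happens when free hydroxyl groups replace the two acetate esters.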